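Iodine placement on the benzyl thiourea arm

The source may hold more compounds than are shown below. What is called first, only, known or untested is meant among the compounds shown, and "the series" means these compounds.

Two members of the series have numbers in an assay on CHO cells for displacement of a labelled ligand from transient receptor potential cation channel subfamily V member 1 (Rattus norvegicus); on this read-out higher numbers stand for weaker inhibition and lower numbers for stronger inhibition. Compound 1 `COc1cc(CNC(=S)NCC(COC(=O)C(C)(C)C)Cc2ccc(C(C)(C)C)cc2)c(I)cc1O` gives 13.3 nM in this assay. Compound 2 `COc1cc(CNC(=S)NCC(COC(=O)C(C)(C)C)Cc2ccc(C)c(C)c2)cc(I)c1O` gives 232 nM in this assay, the highest of the two numbers shown; its only neighbour is compound 1, which sits well below it. For the measured compounds named here, no single-point step joins compound 1 and compound 2, as they differ at more than one place, so the two values are taken as they stand.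

Compound 3 `COc1cc(CNC(=S)NCC(COC(=O)C(C)(C)C)Cc2ccc(C)c(C)c2)c(I)cc1O` is not yet measured. It differs from compound 2 in one place: 4-hydroxy-2-iodo-5-methoxyphenyl in place of 4-hydroxy-3-iodo-5-methoxyphenyl on a saturated chain carbon bound to an amide-type nitrogen. Compound 1 carries the same 4-hydroxy-2-iodo-5-methoxyphenyl group as compound 3, while differing from it elsewhere, so the contrast between compound 1 and compound 2 offers only a loose hint, not a clean step. A move toward lower numbers in this assay is expected for compound 3, of moderate size, though the uncertainty stays wide. The step from compound 2 to compound 3 that this expectation implies is a 3.3-fold lower number from compound 2 to compound 3 (0.52 log units; beyond the scatter). Compound 3 is estimated at 70 nM, within a range of 25 nM to 200 nM.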

Compound 3, inhibition constant: 18.9 nM
Beside the measured number, compound 3's estimate is 3.7-fold (0.57 log units) above it; the whole stated range lies above it.
By their numbers in this assay, from the lowest: compounds 1 and 3 (each within the scatter of the next); then compound 2.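

Moving the iodine, with the same atoms joined differently, has a large effect in this assay: 4-hydroxy-2-iodo-5-methoxyphenyl in place of 4-hydroxy-3-iodo-5-methoxyphenyl gives a 12-fold lower number from compound 2 to compound 3 (1.09 log units; beyond the scatter), the first single-place reading of this position in the series. With the 4-hydroxy-2-iodo-5-methoxyphenyl group held fixed, 3,4-dimethylphenyl in place of 4-(tert-butyl)phenyl gives a 1.4-fold higher number from compound 1 to compound 3 (0.15 log units; within the scatter), so these two groups are not told apart in this read-out, and of the two steps only the iodine step lies beyond the scatter. Nothing measured on these compounds bears on the origin of the iodine step.

From the compounds shown here alone, the iodine step rests on a single pair carrying 3,4-dimethylphenyl, so whether it holds with 4-(tert-butyl)phenyl or other groups on that arm remains open. Also open, going by these compounds, is how bromine, chlorine or plain hydrogen would read in place of the iodine, and whether a carboxylic acid or an amide could stand in place of the ester on the chain.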